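The source may report more compounds than this note shows. Statements on the series, on what has been measured and on what is new or still open speak of the compounds shown alone.

Measured compounds in a functional assay on isolated protein for agonist activity at Glucose-dependent insulinotropic receptor (Homo sapiens), read by HTRF and cAMP accumulation; on this read-out higher numbers stand for larger maximal responses and lower numbers for smaller maximal responses:
- compound 1 `CC(C)(C)OC(=O)N1CCC(O[C@H]2CC[C@@H](Oc3ccc(S(C)(=O)=O)cc3)CC2)CC1`: 120%
- compound 2 `CC(C)(C)OC(=O)N1CCC(O[C@H]2CC[C@H](Oc3ccc(S(C)(=O)=O)cc3)CC2)CC1`: 115%
- compound 3 `Cc1nc(O[C@H]2CC[C@H](OC3CCN(C(=O)OC(C)(C)C)CC3)CC2)ccc1C(=O)N(C)C`: 121%

Compound 2 sits within the scatter of both other compounds: the mirror-image pair gives a number 5 percentage points lower from compound 1 to compound 2 (within the scatter), and the gap between compound 2 and compound 3 is also inside the usual scatter, so no ordering among the three can be claimed.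

The move to compound 4 `CC(C)(C)OC(=O)N1CCC(O[C@H]2CC[C@H](Oc3cnc(C#N)cn3)CC2)CC1` is 5-cyanopyrazin-2-yl in place of 4-(methylsulfonyl)phenyl on an oxygen on a saturated carbon. For the measured compounds named here, no measured pair reproduces this exchange. Going by the values given here, the only measured step, a number 5 percentage points lower from compound 1 to compound 2 (within the scatter), rests on the fact that compounds 1 and 2 differ only in the configuration as drawn and is inside the scatter, so it says nothing about replacing the aromatic group on that oxygen. Compound 3, which carries a different group on that oxygen, reaches a maximal response in the same range as compound 2, but no single-step comparison between them is available.

The expectation for compound 4 in this assay is therefore a maximal response close to that of compound 2. Compound 4 is expected to show no change at the digits printed from compound 2 to compound 4 (within the scatter), nothing beyond the scatter. The estimate for compound 4 is 115%, range 95% to 135%.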

Compound 4, largest response reached (Emax), in percent of the reference or control that the assay uses: 110%
Compound 4: the middle estimate sits 5 percentage points above what was measured; the measured number falls inside the stated range.
By their numbers in this assay, from the lowest: compounds 4, 2, 1 and 3 (each within the scatter of the next, the first and the last beyond it).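

For the compounds shown here, replacing 4-(methylsulfonyl)phenyl with 5-cyanopyrazin-2-yl on an oxygen on a saturated carbon gives a number 5 percentage points lower from compound 2 to compound 4 (within the scatter) in this assay, the first single-step reading of an exchange of the aromatic group at this place. The maximal response therefore does not move beyond the scatter when a six-membered aromatic ring of carbon only gives way to one with 2 hetero atoms, or when the sulfur-bearing substituent gives way to a nitrile. Nothing measured here accounts for the outcome of this exchange.

Still open, going by these compounds, is whether this place keeps the same maximal response with a carboxylic acid, an amine or a longer alkyl chain in place of the aromatic group. These numbers also leave open how potency follows the same exchange, since only the maximal response is read here.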